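The source may hold more compounds than are shown below. What is called first, only, known or untested is meant among the compounds shown, and "the series" means these compounds.

Two compounds have numbers in a functional assay on PC-3 cells (Homo sapiens) for cytotoxicity, read by MTT assay, with a stated time of 72 h; a higher number here means a weaker inhibitor, a lower number a stronger inhibitor. Compound 1 `COc1ccc2c(c1)c(CC(=O)OCCC[Se]C(F)(F)F)c(C)n2C(=O)c1ccc(Cl)cc1` gives 7800 nM in this assay. Compound 2 `Cc1cccc(Nc2ccccc2C(C)C(=O)OCCC[Se]C#N)c1C` gives 33200 nM in this assay, the higher of the two numbers; the gap to compound 1 lies beyond the scatter, but the two compounds differ in several places, so it says nothing about any single change. Compound 3 `Cc1cccc(Nc2ccccc2C(C)C(=O)OCCC[Se]C(F)(F)F)c1C` keeps the core of compound 2 and differs from it in one place: trifluoromethyl in place of cyano on a selenium. Among the measured compounds shown here, no measured pair isolates this change. For the measured compounds named here, the one compound carrying trifluoromethyl on selenium, compound 1, shows the lower number 7800 nM, a weak hint at best. The step is expected to be a modest lowering, a 2.2-fold lower number from compound 2 to compound 3 (0.35 log units; beyond the scatter), with little confidence in either size or direction. Compound 3 is accordingly estimated at 15000 nM in this assay, within a range from 5000 nM to 45000 nM.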

Compound 3, half-maximal inhibitory concentration: 24500 nM
Compound 3: middle estimate off by 1.6-fold (0.21 log units), on the low side; the measured number falls inside the stated range.
By their numbers in this assay, from the lowest: compound 1; then compounds 3 and 2 (each within the scatter of the next).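

Among the compounds shown here, this is the first one-place comparison at this selenium, whose other neighbour is a saturated chain carbon. Trifluoromethyl in place of cyano reads in this assay as a 1.4-fold lower number from compound 2 to compound 3 (0.13 log units; within the scatter) and so the two groups cannot be told apart on the core of compound 2. The hint drawn from compound 1 therefore finds no support in this pair, and nothing on hand accounts for the two groups reading alike.

On these data alone, whether the same holds on the core of compound 1 remains open. Also open, as far as these compounds go, is how a methyl group on the selenium, or a sulfur atom in the place of the selenium, would read in this assay against these two groups.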